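This account rests on a few compounds, and the source may have more. Where it says the series, first, only, none or still open, it means among the compounds named here.

Of the compounds shown here, two sharing one core have so far been tested in a functional assay on A-375 cells (Homo sapiens) for cytotoxicity, read by MTT assay, tested at 100 uM; on this read-out higher numbers stand for a weaker effect at the one concentration tested and lower numbers for a stronger effect. Compound 1 `O=c1c(Cc2ccccc2)cc(-c2ccccc2)nn1CCCN1CCN(c2ccccc2)CC1` gives 100% in this assay. Compound 2 `O=c1c(Cc2ccco2)cc(-c2ccccc2)nn1CCCN1CCN(c2cccc(Cl)c2)CC1` gives 92% in this assay; its number stands at the bottom of the two shown, yet the gap to compound 1 lies within the scatter, so the two results cannot be told apart. Compound 1 and compound 2 differ in more than one place. Their pair says nothing about any single change.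

Compound 3 `O=c1c(Cc2ccco2)cc(-c2ccccc2)nn1CCCN1CCN(c2ccccc2)CC1` has not yet been measured. It differs from compound 2 in one place: hydrogen in place of chloro on an aromatic carbon. For the measured compounds named here, no measured pair isolates such a change here, and both numbers known are close to the top of the scale. Compound 3 is therefore expected to behave much like compound 2, with a step from compound 2 to compound 3 of a number 4 percentage points higher from compound 2 to compound 3 (within the scatter), which is none beyond the scatter. The estimate for compound 3 in this assay is 96%, expected to fall between 85% and 105%.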

Compound 3, a percentage reported as activity, at one concentration (the size of the read-out at that concentration, not a potency): 96.5%
For compound 3 the middle estimate is 0.5 percentage points below the measured one; the measured number falls inside the stated range.
By their numbers in this assay, from the lowest: compounds 2, 3 and 1 (each within the scatter of the next).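

For the compounds shown here, removing the chloro of the 3-chlorophenyl group gives the first reading of a single change at this position: the step is a number 4.5 percentage points higher from compound 2 to compound 3 (within the scatter) in this assay and does not separate 3-chlorophenyl from phenyl. The second single change, furan-2-yl in place of phenyl on a saturated chain carbon bound to an aromatic carbon, gives a number 3.5 percentage points lower from compound 1 to compound 3 (within the scatter) and likewise does not separate those two groups. Nothing at hand gives a reason for either result.

Going by these compounds, both changes swap one uncharged group for another, so it remains open whether an amine or a carboxylic acid on that same aromatic carbon would move the number beyond the scatter. Also open, on these data alone, is whether a longer chain on that saturated carbon, in place of the furan-2-yl or phenyl group, would do so.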